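Methoxy Added to a Benzyl Amidine: Cytotoxicity Outlook

The source may hold more compounds than are shown below. What is called first, only, known or untested is meant among the compounds shown, and "the series" means these compounds.

Measured so far:
compound 1, `N=C(NCc1ccccc1)[C@@H]1CCC(=O)N1Cc1ccccc1`, 27.9%
compound 2, `N=C(NCc1ccccc1)[C@@H]1CCC(=O)N1Cc1ccccc1[N+](=O)[O-]`, 28.8%

In a functional assay on SH-SY5Y cells (Homo sapiens) for cytotoxicity, read by MTT assay, with stated times of 8 h, 30 min and 12 h, tested at 0.5 uM (on this read-out lower numbers stand for a weaker effect and higher numbers for a stronger effect at the one concentration tested), compound 1 gives 27.9%, and compound 2 gives 28.8%. Going by the values given here, the only measured step is a number 0.9 percentage points higher from compound 1 to compound 2 (within the scatter), which came with nitro in place of hydrogen on an aromatic carbon. Compound 2 thus holds the higher of the two numbers, but its nearest neighbour, compound 1, sits within the scatter of it, so the two cannot be ordered.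

Compound 3, `COc1ccc(CNC(=N)[C@@H]2CCC(=O)N2Cc2ccccc2[N+](=O)[O-])cc1`, differs from compound 2 in one place: methoxy in place of hydrogen on an aromatic carbon. Among the compounds with values here, no measured step involves a methoxy group; the single step known, from a substituent placed on an aromatic carbon, was small. Compound 3 is therefore expected to show a step of a number 1.2 percentage points higher from compound 2 to compound 3 (within the scatter), that is, none beyond the scatter. For compound 3 the estimate is 30%, within a range of 15% to 45%.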

Compound 3, a percentage reported as activity, at one concentration (the size of the read-out at that concentration, not a potency): 21.1%
For compound 3 the middle estimate is 8.9 percentage points above the measured one, and the stated range covers the measured number.
By their numbers in this assay, from the lowest: compounds 3, 1 and 2 (each within the scatter of the next).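

In this assay, going by these compounds alone, the step of a number 7.7 percentage points lower from compound 2 to compound 3 (within the scatter) is the first reading for a substituent on this aromatic carbon, on the benzyl group that carries no nitro group in compound 2. Compound 2 and compound 3 cannot be told apart here, so the benzyl to 4-methoxybenzyl replacement shows no effect that can be separated from the scatter, and the nitro step on the other benzyl group is likewise within it. No other measurement bears on why this reading falls where it does. The compounds shown leave open whether an amine or a carboxylic acid on this carbon, or a longer chain such as ethoxy in place of methoxy, would give a number beyond the scatter. They also leave open whether methoxy would read the same on compound 1, which has no nitro group.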